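Swapping an Aryl Ether for a Biaryl on a Quinoline Core

The compounds below may be only part of what the source reports. "The series", "measured", "known", "first", "only" and "open" are said of these compounds alone.

Of the compounds shown here, three have been measured in an ADME assay for permeability, using PAMPA, with a stated time of 30 min, at pH 7.4; on this read-out higher numbers stand for higher permeability and lower numbers for lower permeability. Compound 1 `COc1ccccc1Oc1ccc2c(NCCCNCc3ccco3)ccnc2c1` gives 317 10^-6 cm/s, the highest of the three numbers. Compound 2 `COc1ccc(F)cc1CNCCCNc1ccnc2cc(Cc3cc(C)cc(C)c3)ccc12` gives 23 10^-6 cm/s, and compound 3 `COc1ccc(F)cc1CNCCCNc1ccnc2cc(CCC(C)C)ccc12` gives 23 10^-6 cm/s; both sit well below compound 1, beyond the scatter. Going by the values given here, the one measured step, no change at the digits printed from compound 2 to compound 3 (within the scatter), changes a saturated chain carbon and leaves the read-out unchanged within the scatter, so it says little about a change on an aromatic carbon of the shared core.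

Compound 4 `Fc1ccc(-c2ccc3c(NCCCNCc4ccco4)ccnc3c2)cc1` differs from compound 1 by one change: 4-fluorophenyl in place of 2-methoxyphenoxy on an aromatic carbon. Among the compounds with values here, no measured pair shows this kind of exchange, so the expectation rests on compound 1 alone, whose value of 317 10^-6 cm/s already stands at the top of this small set. Within the data shown here, with no step to guide the direction, the estimate for compound 4 is 250 10^-6 cm/s, with a range from 100 10^-6 cm/s to 600 10^-6 cm/s. The step this estimate means, a 1.3-fold lower number from compound 1 to compound 4 (0.10 log units; within the scatter), is expected to stay within the scatter.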

Compound 4, apparent permeability: 237 10^-6 cm/s
The estimate for compound 4 lay 1.1-fold (0.02 log units) above the measured number; measured number inside the range.
By their numbers in this assay, from the lowest: compounds 2 and 3 (each within the scatter of the next); then compounds 4 and 1 (each within the scatter of the next).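

In this assay, going by these compounds alone, this is the first measured change on the aromatic carbon of the shared core, and putting 4-fluorophenyl in place of 2-methoxyphenoxy gives a 1.3-fold lower number from compound 1 to compound 4 (0.13 log units; within the scatter), so the two compounds cannot be told apart on this read-out. In this one pair, the group that leaves has 9 heavy atoms and 2 hydrogen-bond acceptors and the group that enters has 7 heavy atoms and 0 hydrogen-bond acceptors, yet the numbers stay within the scatter of each other. No measurement shown here offers a reason for this outcome.

As far as these compounds go, whether the read-out would hold with a different kind of group at this position, such as an amine or a carboxylic acid, remains open. From the compounds shown here alone, it is also open whether the same exchange would give a similar result with the other side chain carried by compound 2 and compound 3.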